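The compounds below may be only part of what the source reports. "The series", "measured", "known", "first", "only" and "open" are said of these compounds alone.

Measured compounds:
Compound 1 `CS(=O)(=O)CCCn1c(Cn2cc(S(C)(=O)=O)c3cc(F)ccc32)nc2cc(Cl)ccc21`. In an ADME assay on HEp-2 cells (Homo sapiens) for cytotoxicity, with a stated time of 4 days (on this read-out lower numbers stand for higher toxicity in this test and higher numbers for lower toxicity in this test), compound 1 gives > 100000 nM, which is a limit of the assay.
Compound 2 `CS(=O)(=O)c1nn(Cc2nc3cc(Cl)ccc3n2CCCO)c2cnccc12`. In this assay compound 2 gives > 100000 nM, which is a limit of the assay.
Compound 3 `CS(=O)(=O)c1nn(Cc2nc3cc(Cl)ccc3n2CCOCCO)c2cnccc12`. In this assay compound 3 gives > 100000 nM, which is a limit of the assay.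

Compound 3 therefore stands only at a limit in this assay, and the two other values shown are limits as well. Going by the values given here, the one change within the measured set, a step that the two limits leave unreadable from compound 2 to compound 3, stays unreadable for the same reason; all that can be said is the limit of > 100000 nM in this assay, at which 3 of the 3 values shown sit.

Compound 4 `CS(=O)(=O)c1nn(Cc2nc3cc(Cl)ccc3n2CC2COC2)c2cnccc12` differs from compound 3 in oxetan-3-yl in place of (2-hydroxyethoxy)methyl on a saturated chain carbon bound to an aromatic nitrogen. No measured step bears on this change with a readable size, so no step beyond the scatter can be derived from the numbers shown. The expectation is that a step that the limit leaves unreadable from compound 3 to compound 4 again ends at the limit, given (the limit of > 100000 nM in this assay, at which 3 of the 3 values shown sit). For compound 4 the estimate in this assay is 150000 nM, with an expected range from 50000 nM to 500000 nM, and most probably only a limit will be reported.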

Compound 4, half-maximal cytotoxic concentration: > 100000 nM
Compound 4 was reported as a limit; the forecaster's own chance of this, stated with the estimate: 85%; the middle value does not contradict the limit.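

Compound 4 also sits at a limit in this assay, so no step can be read among compound 2, compound 3 and compound 4: the limit of > 100000 nM in this assay, at which 4 of the 4 values shown sit. The compounds shown leave open whether any of these chain changes alters the half-maximal cytotoxic concentration, since none gives a value that is not a limit.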